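Amide to urea on a shared pyrazole-free core: compound 4

This account rests on a few compounds, and the source may have more. Where it says the series, first, only, none or still open, it means among the compounds named here.

Measured compounds:
- Compound 1 `COc1cc(-c2nn(-c3cccc(NC(=O)c4cccc(C(F)(F)F)c4)c3)cc2-c2ccncc2)ccc1Cl`: 1020 nM
- Compound 2 `COc1cc(-c2nn(-c3cccc(NC(=O)Nc4ccc(Cl)c(Cl)c4)c3)cc2-c2ccncc2)ccc1Cl`: 690 nM
- Compound 3 `COc1cc(-c2nn(-c3cccc(NC(=O)c4ccc(Cl)c(C(F)(F)F)c4)c3)cc2-c2ccncc2)ccc1Cl`: 1380 nM

All three were tested in a functional assay on SF-295 cells (Homo sapiens) for inhibition, read by sulforhodamine B assay, with a stated time of 48 h; on this read-out higher numbers stand for weaker inhibition and lower numbers for stronger inhibition. Compound 3 gives the highest of the three numbers, but the step of a 1.4-fold higher number from compound 1 to compound 3 (0.13 log units; within the scatter) and the step of a 2.0-fold higher number from compound 2 to compound 3 (0.30 log units; within the scatter) both fall within the usual scatter, so no real difference among them is shown.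

Compound 4 `COc1cc(-c2nn(-c3cccc(NC(=O)Nc4ccc(Cl)c(C(F)(F)F)c4)c3)cc2-c2ccncc2)ccc1Cl` differs from compound 3 in one place: (4-chloro-3-(trifluoromethyl)phenyl)amino in place of 4-chloro-3-(trifluoromethyl)phenyl on a carbonyl carbon. The same kind of exchange, an amide replaced by a urea with an altered aromatic ring, appears in the step of a 1.5-fold lower number from compound 1 to compound 2 (0.17 log units; within the scatter), and in reverse in the step of a 2.0-fold higher number from compound 2 to compound 3 (0.30 log units; within the scatter). Both movements are small and within the scatter. Compound 4 is therefore expected to show a slightly lower number in this assay, a step of a 1.6-fold lower number from compound 3 to compound 4 (0.21 log units; within the scatter), not clearly beyond the scatter. The estimate for compound 4 is 850 nM, with a range from 400 nM to 1900 nM.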

Compound 4, half-maximal inhibitory concentration: 840 nM
Estimate against measurement, compound 4: 1.0-fold (0.01 log units) above; the range from low to high includes it.
By their numbers in this assay, from the lowest: compounds 2, 4, 1 and 3 (each within the scatter of the next).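

In this assay the 4-chloro-3-(trifluoromethyl)phenyl ring now stays the same on both sides of a pair, so the amino group entering on the carbonyl carbon can be read alone: it gives a 1.6-fold lower number from compound 3 to compound 4 (0.22 log units; within the scatter) and shows no real difference between this amide and this urea. Among the ureas, trifluoromethyl in place of chloro on an aromatic carbon gives a 1.2-fold higher number from compound 2 to compound 4 (0.09 log units; within the scatter) and again shows no real difference, as does the change of the whole group from the 3-(trifluoromethyl)phenyl amide, which gives a 1.2-fold lower number from compound 1 to compound 4 (0.08 log units; within the scatter) and leaves these compounds indistinguishable. Nothing measured here offers an explanation for these small steps.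

Still open, from the compounds shown here alone, is whether a different link at this place, such as a sulfonamide, would produce a real difference. The same question applies to a longer chain of methylene groups before the aromatic ring, or to a simple alkyl amine on the carbonyl carbon in place of the aromatic ring.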